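This account rests on a few compounds, and the source may have more. Where it says the series, first, only, none or still open, it means among the compounds named here.

Measured compounds:
- compound 1 `C/C(=C\CC/C(C)=C/CC[C@@H]1[C@@]2(C)CCC(=O)C(C)(C)[C@H]2CC[C@@]1(C)O)CC/C=C(\C)C(=O)OCc1cn(-c2ccccc2)nn1` — 95500 nM
- compound 2 `C/C(=C\CC/C(C)=C/CC[C@@H]1[C@@]2(C)CCC(=O)C(C)(C)[C@H]2CC[C@@]1(C)O)CC/C=C(\C)C(=O)OCc1cn(C[C@@H]2O[C@H](n3ccc(=O)[nH]c3=O)[C@H]3OC(C)(C)O[C@H]32)nn1` — > 150000 nM
- compound 3 `C/C(=C\CC/C(C)=C/CC[C@@H]1[C@@]2(C)CCC(=O)C(C)(C)[C@H]2CC[C@@]1(C)O)CC/C=C(\C)C(=O)OCc1cn(-c2ccccc2[N+](=O)[O-])nn1` — > 150000 nM

Going by the values given here, in a functional assay on DU-145 cells (Homo sapiens) for antiproliferative activity, read by MTT assay, with a stated time of 48 h (on this read-out lower numbers stand for stronger inhibition and higher numbers for weaker inhibition), compound 1 gives 95500 nM, the only actual number among the three. For compound 2 the read-out of > 150000 nM is a limit of the assay, not a number. For compound 3 the read-out of > 150000 nM is likewise a limit. Among the compounds with values here, the one step that can be counted runs an at least 1.5-fold higher number from compound 1 to compound 3 (0.19 log units; that floor lies within the scatter); its floor lies within the scatter, yet it shows that placing a group on the phenyl ring of compound 1 did not sharpen the inhibition, and the limit of > 150000 nM in this assay, at which 2 of the 3 values shown sit, is where both other compounds sit.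

Compound 4 `C/C(=C\CC/C(C)=C/CC[C@@H]1[C@@]2(C)CCC(=O)C(C)(C)[C@H]2CC[C@@]1(C)O)CC/C=C(\C)C(=O)OCc1cn(-c2cccc(C(F)(F)F)c2)nn1` differs from compound 1 by trifluoromethyl in place of hydrogen on an aromatic carbon. Within the data shown here, the nitro step is the only related step on record, and it went toward weaker inhibition. A step of similar or slightly larger size in the same direction, to a number near or beyond the assay limit, is therefore expected, written as a 1.6-fold higher number from compound 1 to compound 4 (0.20 log units; within the scatter). The estimate for compound 4 is 150000 nM, within 60000 nM to 350000 nM.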

Compound 4, half-maximal inhibitory concentration: > 150000 nM
Compound 4: no number, only a limit (the forecaster's own chance of this, stated with the estimate: 55%); the middle value lies on the limit itself.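

The value of compound 4 is a limit of the assay and not a number, so trifluoromethyl on the phenyl ring can only be read as an at least 1.5-fold higher number from compound 1 to compound 4 (0.19 log units; that floor lies within the scatter). Nitro in compound 3 gave no sharper inhibition in this assay, and neither does trifluoromethyl in compound 4, so that absence of gain is not confined to the nitro group. The step from compound 3 to compound 4 cannot be read, as both values are limits, and the series now gathers at one point: the limit of > 150000 nM in this assay, at which 3 of the 4 values shown sit.

As far as these compounds go, how far compound 3 and compound 4 lie past that limit stays unknown. Also open, from the compounds shown here alone, is whether an amine, a carboxylic acid or a methoxy group on the phenyl ring of compound 1 would give sharper inhibition.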